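Solubility of quinoline ether amides: toward compound 4

The source may report more compounds than this note shows. Statements on the series, on what has been measured and on what is new or still open speak of the compounds shown alone.

Measured compounds and their kinetic solubility: compound 1 `Cc1cc(C)cc(NC(=O)COc2cc(C)nc3ccccc23)c1` gives 55000 nM; compound 2 `COc1ccc2nc(C)cc(OC(C)(C)C(=O)Nc3cc(C)cc(C)c3)c2c1` gives 20000 nM; compound 3 `COc1ccc2nc(C)cc(OCC(=O)NCc3cc(C)cc(C)c3)c2c1` gives 92000 nM.

In a physicochemical assay for solubility, in phosphate buffer, measured as kinetic solubility, with a stated time of 1 h, at pH 7.4 (a higher number here means a more soluble compound, a lower number a less soluble compound), compound 3 stands highest of the three, with compound 1 nearest and compound 2 furthest. Compound 4 `COc1ccc2nc(C)cc(OCC(=O)Nc3c(C)cccc3C)c2c1` differs from compound 3 by 2,6-dimethylphenyl in place of 3,5-dimethylbenzyl on an amide-type nitrogen. Within the data shown here, no step between two measured compounds matches this change, so the expectation rests on the spread of the three values. Compound 1, also an anilide, gives 55000 nM in this assay, and a similar neighbourhood is expected for compound 4. The estimated step of a 1.8-fold lower number from compound 3 to compound 4 (0.26 log units; within the scatter) is expected to be small, downward, and not clearly beyond the scatter. Compound 4 is therefore estimated at 50000 nM, within a range from 15000 nM to 150000 nM.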

Compound 4, solubility: 112000 nM
Compound 4: middle estimate off by 2.2-fold (0.35 log units), on the low side, and the stated range covers the measured number.
By their numbers in this assay, from the lowest: compound 2; then compounds 1, 3 and 4 (each within the scatter of the next, the first and the last beyond it).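

With 2,6-dimethylphenyl in place of 3,5-dimethylbenzyl on the amide-type nitrogen, this assay gives a 1.2-fold higher number from compound 3 to compound 4 (0.09 log units; within the scatter) and so does not separate the two compounds. The earlier compounds shown here offered no comparison at this place, and this one shows that the swap can be made with no step beyond the scatter. Nothing shown accounts for this result.

From the compounds shown here alone, the swap changes the group's size and its methyl pattern together, so their separate contributions remain open. So does the outcome with an amine, a carboxylic acid or a longer chain on this nitrogen.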